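Swapping the Saturated Ring for Phenyl at the Chain Carbon

The source may report more compounds than this note shows. Statements on the series, on what has been measured and on what is new or still open speak of the compounds shown alone.

Going by the values given here, compound 2 `O=C1NC(=O)/C(=C/C(c2ccc(-c3ccc4cccc(F)c4c3)[nH]c2=O)C2CCCC2)O1` was tested in a functional assay on CHO cells for antagonist activity at prostaglandin E2 receptor EP3 subtype (Homo sapiens), read by cAMP accumulation, with a stated time of 30 min (a lower number here means a stronger inhibitor, a higher number a weaker inhibitor), and gave 7 nM, the lower of the two numbers so far, though the gap to its neighbour is within the scatter. That neighbour, compound 1 `O=C1NC(=O)/C(=C/C(c2ccc(-c3ccc4cccc(F)c4c3)[nH]c2=O)C2CCCCC2)O1`, in this assay gave 8 nM; the step of a 1.1-fold lower number from compound 1 to compound 2 (0.06 log units; within the scatter) shows that trading cyclohexyl for cyclopentyl left the result essentially unchanged. Compound 3 `O=C1NC(=O)/C(=C/C(c2ccccc2)c2ccc(-c3ccc4cccc(F)c4c3)[nH]c2=O)O1` has not yet been measured in this assay. It differs from compound 2 by phenyl in place of cyclopentyl on a saturated chain carbon bound to an aromatic carbon and a double-bonded chain carbon. Among the compounds with values here, the only measured step touching this position, the ring swap just described, was within the scatter, so the place appears to tolerate a different ring. Phenyl is an aromatic ring rather than a saturated one, a larger change with no measured example. The expected step is therefore a 1.3-fold higher number from compound 2 to compound 3 (0.11 log units; within the scatter), nothing beyond the scatter. Compound 3 is expected to give about 9 nM in this assay, within a range from 3 nM to 30 nM.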

Compound 3, half-maximal inhibitory concentration: 190 nM
Compound 3: the middle estimate sits 21-fold (1.32 log units) below what was measured; measured number above the stated range.
By their numbers in this assay, from the lowest: compounds 2 and 1 (each within the scatter of the next); then compound 3.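

In this assay, this position does not treat all rings alike: the move to phenyl gives a 27-fold higher number from compound 2 to compound 3 (1.43 log units; beyond the scatter) and a 24-fold higher number from compound 1 to compound 3 (1.38 log units; beyond the scatter), both large, while cyclohexyl and cyclopentyl stand within the scatter of each other. The tolerance suggested by the earlier pair therefore covers only these two saturated rings and does not extend to the aromatic ring, even though neither the leaving nor the entering group carries hydrogen-bond donors or acceptors. Nothing available here explains why phenyl gives the weaker result.

From the compounds shown here alone, it remains open whether this loss applies to aromatic rings in general or to phenyl alone, a question that a pyridine ring on this chain carbon would help to answer. Going by these compounds, how an open chain such as isopropyl would compare with the saturated rings also remains unknown.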